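This account rests on a few compounds, and the source may have more. Where it says the series, first, only, none or still open, it means among the compounds named here.

In a functional assay on Huh-7 cells (Homo sapiens) for antiproliferative activity, with a stated time of 48 h (a lower number here means a stronger inhibitor, a higher number a weaker inhibitor), compound 2 `CCOC(=O)c1ccc(-c2ccc(N(C)C)nn2)cc1` gives > 25000 nM, which is a limit and not a number. Compound 3 `COC(=O)c1ccc(-c2ccc(N(C)C)nn2)cc1` gives > 25000 nM, again a limit. Both therefore stand at the limit of > 25000 nM in this assay, at which 2 of the 3 values shown sit. Compound 1 `CCN(CC)c1ccc(-c2ccc(C(=O)OC)cc2)nn1`, on the shared core, gives a real number of 90 nM.

The step followed here leads to compound 4 `CCCCOc1ccc(-c2ccc(C(=O)OCC)cc2)nn1`. The change is butoxy in place of dimethylamino on an aromatic carbon, para to a large group.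

Within the data shown here, two measured steps bear on it. Among the measured compounds shown here, the first changes the group on that same aromatic carbon and shows an at least 270-fold higher number from compound 1 to compound 3 (2.44 log units; beyond the scatter), a large step beyond the scatter. The group at this place can thus decide between a strong number and none at all. The second, a step that the two limits leave unreadable from compound 2 to compound 3, gives no size to carry over.

For the measured compounds named here, no measured compound carries butoxy, so the data only loosely fix the outcome. Resting on the step of an at least 270-fold higher number from compound 1 to compound 3 (2.44 log units; beyond the scatter), a move to a lower number in this assay is expected, though compound 4 could also remain at the limit. The expected step is an at least 10-fold lower number from compound 2 to compound 4 (1.00 log units; beyond the scatter). For compound 4 the estimated value is 2500 nM, with an expected range from 150 nM to 25000 nM.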

Compound 4, half-maximal inhibitory concentration: > 25000 nM
Compound 4: a limit, no number (the forecaster's own chance of this, stated with the estimate: 35%); middle value at least 10-fold (1.00 log units) from the limit.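

In this assay compound 4 gives > 25000 nM, which is a limit and not a number. Among these compounds, compound 2 gives > 25000 nM, also a limit, so no step between compound 2 and compound 4 can be read. The compounds shown leave open whether any compound carrying butoxy would give a real number in this assay.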